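Shortening the amide acyl chain with a chloro terminus

The source may hold more compounds than are shown below. What is called first, only, known or untested is meant among the compounds shown, and "the series" means these compounds.

In a functional assay on MCF7 cells (Homo sapiens) for antiproliferative activity, read by sulforhodamine B assay, with a stated time of 48 h (a higher number here means a weaker inhibitor, a lower number a stronger inhibitor), compound 1 `CCCCCC(=O)Nc1ccc(S(=O)(=O)Oc2ccccc2C(C)C)cc1` gives 5300 nM, compound 2 `CC(C)C(=O)Nc1ccc(S(=O)(=O)Oc2ccccc2C(C)C)cc1` gives 8600 nM, and compound 3 `CC(C)c1ccccc1OS(=O)(=O)c1ccc(NC(=O)C(C)(C)C)cc1` gives 6500 nM. Compound 3 thus sits between the other two numbers, and none of the three separate beyond the scatter: a 1.6-fold higher number from compound 1 to compound 2 (0.21 log units; within the scatter), a 1.2-fold higher number from compound 1 to compound 3 (0.09 log units; within the scatter), a 1.3-fold lower number from compound 2 to compound 3 (0.12 log units; within the scatter). Compound 4 `CC(C)c1ccccc1OS(=O)(=O)c1ccc(NC(=O)CCCl)cc1` arises from compound 3 through (2-chloroethyl in place of tert-butyl on a carbonyl carbon). All three measured steps change the same acyl group on this amide and each stayed within the scatter, so another flat step in this assay is the expectation, with a 1.1-fold higher number from compound 3 to compound 4 (0.03 log units; within the scatter) estimated. Compound 4 is therefore expected at 7000 nM, ranging from 3000 nM to 17000 nM.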

Compound 4, half-maximal inhibitory concentration: 9000 nM
Beside the measured number, compound 4's estimate is 1.3-fold (0.11 log units) below it; the measured number falls inside the stated range.
By their numbers in this assay, from the lowest: compounds 1, 3, 2 and 4 (each within the scatter of the next).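

The first acyl group carrying chlorine, 2-chloroethyl, leaves this position as flat as the purely hydrocarbon groups did in this assay, with every new step within the scatter (a 1.4-fold higher number from compound 3 to compound 4 (0.14 log units; within the scatter)) (a 1.0-fold higher number from compound 2 to compound 4 (0.02 log units; within the scatter)) (a 1.7-fold higher number from compound 1 to compound 4 (0.23 log units; within the scatter)). Chlorine on the chain therefore adds no separation among the four amides, whether it replaces tert-butyl, isopropyl or the propyl end of the pentyl chain. Nothing available accounts for this flatness. Going by these compounds, whether a terminal amine, a carboxylic acid or a longer chloroalkyl chain would move the number beyond the scatter remains open.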